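The source may report more compounds than this note shows. Statements on the series, on what has been measured and on what is new or still open speak of the compounds shown alone.

Compound 1 `COc1ccc(-c2cnc3nc(N)nc(N4CCN(C(=O)COc5ccccc5)CC4)c3n2)cc1OC` gives the lowest of the two numbers recorded in a functional assay on cells (T-cell, Homo sapiens) for inhibition (on this read-out higher numbers stand for weaker inhibition and lower numbers for stronger inhibition), where compound 1 gives 4 nM. Among the measured compounds shown here, compound 2 `COc1ccc(-c2cnc3nc(N)nc(OC(C)C)c3n2)cc1OC` differs from compound 1 in the group attached to the shared core, and in this assay compound 2 gives 400 nM; no single step is drawn between these two compounds, so the two values stand on their own. Compound 3 `COc1ccc(-c2cnc3nc(N)nc(OC(C)C)c3n2)cc1` reaches only a limit of this assay, > 10000 nM. For the measured compounds named here, the one measured step, an at least 25-fold higher number from compound 2 to compound 3 (1.39 log units; beyond the scatter), concerns hydrogen in place of methoxy on an aromatic carbon and rests on the fact that one value sits at the limit, as noted under (the limit of > 10000 nM in this assay, at which 1 of the 3 values shown sits).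

Compound 4 `COc1ccc(-c2cnc3nc(N)nc(N4CCN(Cc5c(Cl)cccc5Cl)CC4)c3n2)cc1OC` is not yet measured. It differs from compound 1 by 2,6-dichlorobenzyl in place of (phenoxymethyl)carbonyl on an amine nitrogen in a ring. Going by the values given here, no measured step touches the amine nitrogen in the ring, and the step from compound 2 to compound 3 lies on a different part of the molecule, so it gives no direct guide. Compound 4 is therefore expected to land near compound 1, with the step of a 5.0-fold higher number from compound 1 to compound 4 (0.70 log units; beyond the scatter) estimated as a modest loss at most. Compound 4 is expected to give about 20 nM, in a range from 3 nM to 150 nM.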

Compound 4, half-maximal inhibitory concentration: 7600 nM
Estimate against measurement, compound 4: 380-fold (2.58 log units) below; measured number above the stated range.
By their numbers in this assay, from the lowest: compound 1; then compound 2; then compound 4. At a limit, above all of these: compound 3.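

Among the compounds shown here, exchanging (phenoxymethyl)carbonyl for 2,6-dichlorobenzyl on the amine nitrogen in a ring gives a 1900-fold higher number from compound 1 to compound 4 (3.28 log units; beyond the scatter) in this assay, so this position, which no earlier step touched, is far from indifferent to what it carries. The change takes away the carbonyl and the hydrogen-bond acceptors counted in the leaving group and brings in two chlorine atoms, and in this single step these differences travel together, so it cannot tell which of them counts. Nothing measured here gives a reason for the size of this step.

The compounds shown leave open whether an unsubstituted benzyl on the same nitrogen would stay near compound 1 or fall toward compound 4. From the compounds shown here alone, it also remains open whether a small acetyl there would keep the value of compound 1.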